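The compounds below may be only part of what the source reports. "The series", "measured", "known", "first", "only" and "open" are said of these compounds alone.

Compound 1, `COc1ccc(/C=C/C(=O)c2cc(-c3ccc(OC)c(OC)c3)n3nc(-c4ccccc4)cc3n2)cc1`, gives 22000 nM in a functional assay on MDA-MB-231 cells (Homo sapiens) for antiproliferative activity, read by MTT assay, with a stated time of 24 h; on this read-out higher numbers stand for weaker inhibition and lower numbers for stronger inhibition.
Compound 2, `COc1ccc(-c2cc(C(=O)/C=C/c3ccc(C)cc3)nc3cc(-c4ccccc4)nn23)cc1OC`, gives 22600 nM in this assay.
Compound 3, `COc1ccc(/C=C/C(=O)c2cc(-c3cc(OC)c(OC)c(OC)c3)n3nc(-c4ccccc4)cc3n2)cc1`, gives 16500 nM in this assay.

All three measured compounds share a core and differ only in the groups on two outer rings. Compound 4, `COc1cc(-c2cc(C(=O)/C=C/c3ccc(C)cc3)nc3cc(-c4ccccc4)nn23)cc(OC)c1OC`, has not yet been measured in this assay.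

Compound 4 is made from compound 3 by one change: methyl in place of methoxy on an aromatic carbon. The same change has already been made once among the measured compounds, from compound 1 to compound 2: methyl in place of methoxy on an aromatic carbon. In this assay that step was a 1.0-fold higher number from compound 1 to compound 2 (0.01 log units; within the scatter), so the number hardly moved.

Compound 3 and compound 1 differ in their cores in the following way: methoxy in place of hydrogen on an aromatic carbon. In this assay this step was a 1.3-fold lower number from compound 1 to compound 3 (0.12 log units; within the scatter), also a small move. The place of the change from compound 3 to compound 4 reads word for word the same as the place of the change from compound 1 to compound 2, so it counts as the same change made on a slightly different core.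

Because the earlier step of a 1.0-fold higher number from compound 1 to compound 2 (0.01 log units; within the scatter) stayed within the scatter, the step from compound 3 to compound 4 in this assay is expected to be of about the same size, a 1.0-fold higher number from compound 3 to compound 4 (0.01 log units; within the scatter). Compound 4 is therefore estimated at 17000 nM in this assay, with the usual range of repeats running from 8500 nM to 34000 nM.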

Compound 4, half-maximal inhibitory concentration: 18600 nM
The estimate for compound 4 lay 1.1-fold (0.04 log units) below the measured number; measured number inside the range.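

In this assay, for the compounds shown here, putting methyl in place of methoxy on the outer ring gave a 1.1-fold higher number from compound 3 to compound 4 (0.05 log units; within the scatter), and this step agrees with the same change made earlier on the core of compound 1: the same change on two cores in this assay, a 1.0-fold higher number (0.01 log units; within the scatter) from compound 1 to compound 2 and a 1.1-fold higher number (0.05 log units; within the scatter) from compound 3 to compound 4, 1.1-fold (0.04 log units) apart, within the scatter of two such steps Putting methoxy in place of hydrogen gave a 1.2-fold lower number from compound 2 to compound 4 (0.08 log units; within the scatter), and this step also agrees with its earlier counterpart: the same change on two cores in this assay, a 1.3-fold lower number (0.12 log units; within the scatter) from compound 1 to compound 3 and a 1.2-fold lower number (0.08 log units; within the scatter) from compound 2 to compound 4, 1.1-fold (0.04 log units) apart, within the scatter of two such steps So each change behaved alike on the two cores, but all four steps are small enough to sit within the scatter, which shows only that these two changes hardly register on either core, not that a change with a clear effect would carry over in the same way, nor that other cores would follow.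

The compounds shown carry only methoxy, methyl or hydrogen at the places that vary, so it remains open what an amine, a carboxylic acid or a longer alkoxy chain would do there, and whether such a step would stay the same size from one core to the other. Going by these compounds, whether these steps also look alike in other cell lines or at other exposure times remains open as well.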